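Swapping a Sulfonamide Ring on a Chloro Aryl Acid

The compounds below may be only part of what the source reports. "The series", "measured", "known", "first", "only" and "open" are said of these compounds alone.

In an assay on CHO cells for displacement of a labelled ligand from prostaglandin D2 receptor 2 (Homo sapiens), read by scintillation counting (on this read-out higher numbers stand for weaker inhibition and lower numbers for stronger inhibition), compound 2 `Cc1ccc(S(=O)(=O)N2CCOCC2)cc1C#Cc1cc(Cl)ccc1OCC(=O)O` gives 3.6 nM, and compound 1 `Cc1ccc(S(=O)(=O)NC(C)C)cc1C#Cc1cc(Cl)ccc1OCC(=O)O` gives 3.4 nM; the two numbers sit within the scatter of each other. Compound 3 `Cc1ccc(S(=O)(=O)N2CCCCC2C)cc1C#Cc1cc(Cl)ccc1OCC(=O)O` differs from compound 2 only by 2-methylpiperidin-1-yl in place of morpholin-4-yl on a sulfonyl sulfur. Among the measured compounds shown here, the sole measured step that bears on this change is also at the sulfonyl sulfur: a 1.1-fold higher number from compound 1 to compound 2 (0.02 log units; within the scatter), which stayed within the scatter. The expected step is therefore a 1.1-fold higher number from compound 2 to compound 3 (0.05 log units; within the scatter) in this assay, with no clear direction and nothing beyond the scatter foreseen. Compound 3 is estimated at 4 nM, expected to fall between 1.5 nM and 12 nM.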

Compound 3, inhibition constant: 1.9 nM
The estimate for compound 3 lay 2.1-fold (0.32 log units) above the measured number; measured number inside the range.
By their numbers in this assay, from the lowest: compounds 3, 1 and 2 (each within the scatter of the next).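

In this assay, the sulfonyl sulfur also accepts 2-methylpiperidin-1-yl, which has no ring oxygen and gives a 1.9-fold lower number from compound 2 to compound 3 (0.28 log units; within the scatter) and a 1.8-fold lower number from compound 1 to compound 3 (0.25 log units; within the scatter). Both steps stay within the scatter, so this change, like the earlier one, shows no clear effect at this position. No evidence is available to explain these numbers.

The compounds shown leave open whether plain piperidin-1-yl would match 2-methylpiperidin-1-yl, which would separate the ring methyl from the loss of the ring oxygen. They also leave open whether a piperazin-1-yl ring, with its second ring amine, would move the number beyond the scatter.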